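From Cyclobutyl to 4-Methoxypiperidin-1-yl on a Carbonyl

A few compounds are considered here, and "the series" means these few. Any claim that something is new, unique, unknown or untested is made for them only; others in the source may bear on it.

Compound 1 `O=C(C1CCC1)N1CC(c2nc(-c3cccc(Cl)c3)no2)C1` — in an assay on HEK293 cells for positive allosteric modulation of metabotropic glutamate receptor 5 (Homo sapiens), read by FLIPR (on this read-out lower numbers stand for an effect already at smaller amounts and higher numbers for an effect only at larger amounts of compound), compound 1 gives > 10000 nM, which is a limit of the measurement and not a number.
Compound 2 `O=C(C1CCC(C(F)(F)F)CC1)N1CC(c2nc(-c3cccc(F)c3)no2)C1` — in this assay compound 2 gives 680 nM.

Compound 1 therefore stands at the limit of > 10000 nM in this assay, at which 1 of the 2 values shown sits, so its own position on the scale is not pinned down. Among the compounds with values here, compound 2 carries a different acyl group and a different halogen on the phenyl ring, and no single-change step connects it to compound 1, so the two values are simply two points.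

Compound 3 `COC1CCN(C(=O)N2CC(c3nc(-c4cccc(Cl)c4)no3)C2)CC1` differs from compound 1 in one place: 4-methoxypiperidin-1-yl in place of cyclobutyl on a carbonyl carbon. Since compound 1 has only a limit, any estimate for compound 3 is loosely anchored; the expected step from compound 1 to compound 3 is an at least 2.5-fold lower number from compound 1 to compound 3 (0.39 log units; beyond the scatter), in the direction of an effect at smaller amounts, but with wide uncertainty. In this assay compound 3 is estimated at 4000 nM, between 600 nM and 15000 nM.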

Compound 3, half-maximal effective concentration: > 10000 nM
Compound 3: a limit, no number (the forecaster's own chance of this, stated with the estimate: 45%); middle value at least 2.5-fold (0.39 log units) away from the limit.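

Compound 1 and compound 3 both give a limit and not a number, so no step can be read between them: the limit of > 10000 nM in this assay, at which 2 of the 3 values shown sit. The compounds shown leave open whether 4-methoxypiperidin-1-yl in place of cyclobutyl on a carbonyl carbon changes the result in this assay at all.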